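The compounds below may be only part of what the source reports. "The series", "measured", "known", "first", "only" and "open" are said of these compounds alone.

Working notes on the series. All three measured compounds share one core and differ only in the aryl group that sits on a saturated chain carbon bound to an aromatic carbon. Compound 1 `Cc1c(Cc2cccc(F)c2)c(=O)oc2cc(OCC(O)CN3CCC(C(N)=O)CC3)ccc12` gives 53300 nM in an ADME assay on A549 cells (Homo sapiens) for cytotoxicity, read by CellTiter-Glo; a lower number here means that less compound is tolerated, a higher number that more compound is tolerated. Compound 2 `COc1ccc(Cc2c(C)c3ccc(OCC(O)CN4CCC(C(N)=O)CC4)cc3oc2=O)c(Br)c1` gives 44400 nM in this assay, so a 1.2-fold lower number from compound 1 to compound 2 (0.08 log units; within the scatter). Compound 3 `Cc1c(Cc2ccccc2C(F)(F)F)c(=O)oc2cc(OCC(O)CN3CCC(C(N)=O)CC3)ccc12` reports only a limit in this assay, namely > 100000 nM. That reading sits at the limit of > 100000 nM in this assay, at which 1 of the 3 values shown sits, so where compound 3 stands is known only as a floor, not as a number. The two steps that lead to it are an at least 1.8-fold higher number from compound 1 to compound 3 (0.27 log units; that floor lies within the scatter) and an at least 2.2-fold higher number from compound 2 to compound 3 (0.35 log units; beyond the scatter); the first stays within the scatter, the second is at least modest.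

Compound 4 `COC(=O)c1ccc(Cc2c(C)c3ccc(OCC(O)CN4CCC(C(N)=O)CC4)cc3oc2=O)cc1` is the next member to be measured. Against compound 3 the change is 4-(methoxycarbonyl)phenyl in place of 2-(trifluoromethyl)phenyl on a saturated chain carbon bound to an aromatic carbon. Both measured steps at this place, from compound 1 and from compound 2 to compound 3, moved the number upward toward the limit, while the step from compound 1 to compound 2 did not move it beyond the scatter. Going by the values given here, no measured step covers an ester-bearing aryl group, so the expectation rests on the whole set lying in one region. Compound 4 is therefore expected to show an at least 1.3-fold lower number from compound 3 to compound 4 (0.12 log units; that floor lies within the scatter) in this assay, a change not clearly beyond the scatter and possibly again a limit. Compound 4 is estimated at 75000 nM, within 35000 nM to 160000 nM.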

Compound 4, half-maximal cytotoxic concentration: > 100000 nM
Compound 4 ended at the assay's limit (the forecaster's own chance of this, stated with the estimate: 40%); middle value at least 1.3-fold (0.12 log units) from the limit.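

Compound 4 reports a limit and not a number, so a second, quite different aryl group now reaches the top of the range in this assay: the limit of > 100000 nM in this assay, at which 2 of the 4 values shown sit. The position thus accepts 4-(methoxycarbonyl)phenyl, with 2 hydrogen-bond acceptors and no fluorine, as well as 2-(trifluoromethyl)phenyl, with 0 hydrogen-bond acceptors, and the two steps from the lower compounds repeat what compound 3 showed: an at least 2.2-fold higher number from compound 2 to compound 4 (0.35 log units; beyond the scatter) and an at least 1.8-fold higher number from compound 1 to compound 4 (0.27 log units; that floor lies within the scatter). The step between compound 3 and compound 4 cannot be read, since both are limits, so no order can be set between these two groups, and a limit here is shared by an ortho-free ester-bearing group and a trifluoromethyl-bearing one only as far as these two compounds go.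

The compounds shown leave open how far compound 3 and compound 4 lie past the limit, and so whether the change of aryl group moves the number at all. They also leave open whether a carboxylic acid in place of the methoxycarbonyl group, or an aminomethyl group on the same phenyl ring, would keep the reading at the limit or bring it back into the measurable range.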